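This account rests on a few compounds, and the source may have more. Where it says the series, first, only, none or still open, it means among the compounds named here.

Among the compounds with values here, in a functional assay on DU-145 cells (Homo sapiens) for inhibition, read by trypan blue exclusion, with a stated time of 96 h (on this read-out higher numbers stand for weaker inhibition of growth and lower numbers for stronger inhibition of growth), compound 1 `COc1ccc(/C=C(/SCc2ccc(F)cc2)C(=O)c2ccc(Cl)cc2)c(OC)c1OC` gives 10000 nM, the higher of the two numbers so far. Compound 2 `Cc1ccc(S(=O)(=O)/C(=C/c2ccccc2OCc2ccccc2)C(=O)c2ccc(Br)cc2)cc1` gives 1000 nM, a gap beyond the scatter. Compound 3 `COc1ccc(/C=C(\C(=O)c2ccc(Cl)cc2)S(=O)(=O)Cc2ccc(Cl)cc2)c(OC)c1OC` is not yet measured and differs from compound 1 by (4-chlorobenzyl)sulfonyl in place of (4-fluorobenzyl)sulfanyl on a double-bonded chain carbon bound to a carbonyl carbon and a double-bonded chain carbon, with (4-chlorobenzyl)sulfonyl in place of (4-fluorobenzyl)sulfanyl. Within the data shown here, no measured pair isolates this change. Among the measured compounds shown here, the only guide is compound 2, which carries a sulfonyl group and gives 1000 nM. A step towards stronger inhibition, beyond the scatter, is therefore expected in this assay, estimated as a 10-fold lower number from compound 1 to compound 3 (1.00 log units; beyond the scatter). The estimate for compound 3 is 1000 nM, with an expected range of 150 nM to 6000 nM.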

Compound 3, concentration for 50% growth inhibition: 10000 nM
Compound 3: the middle estimate sits 10-fold (1.00 log units) below what was measured; the measured number lies above the stated range.
By their numbers in this assay, from the lowest: compound 2; then compounds 1 and 3 (each within the scatter of the next).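

In this assay the swap of (4-fluorobenzyl)sulfanyl for (4-chlorobenzyl)sulfonyl on a double-bonded chain carbon bound to a carbonyl carbon and a double-bonded chain carbon gives no change at the digits printed from compound 1 to compound 3 (within the scatter) on the core of compound 1. This position therefore accepts the sulfonyl form and the added oxygens with no shift in growth inhibition. No measurement bearing on the reason for this result is available.

Sulfur form and halogen change together here, so the effect of each alone stays open. Also open, from the compounds shown here alone, is whether an amine or a carboxylic acid on the benzyl group, or a longer chain in its place, would move the number.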